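This account rests on a few compounds, and the source may have more. Where it says the series, first, only, none or still open, it means among the compounds named here.

Working notes on the series.

Of the compounds shown here, three share the amide-linked benzylic core and have been measured in an assay for inhibition of Nicotinamide phosphoribosyltransferase (Homo sapiens), read by mass spectrometry, with stated times of 15 min and 30 min; a higher number here means a weaker inhibitor, a lower number a stronger inhibitor. Compound 1 `O=C(NCc1ccc(S(=O)(=O)c2ccccc2)cc1)c1ccc2nccn2c1` gives 18 nM in this assay. Compound 2 `O=C(NCc1ccc(S(=O)(=O)N2CCCCC2)cc1)c1cc2cnccc2s1` gives 150 nM in this assay. Of the two numbers available, compound 2 carries the higher one and compound 1 the lower; the gap between them lies beyond the usual scatter. Within the data shown here, compound 3 `O=C(NCc1ccc(S(=O)(=O)c2ccccc2)cc1)c1ccc2cnccc2c1` returns only a limit of the assay, > 10000 nM, not a number; it is the one value sitting at the limit described by the limit of > 10000 nM in this assay, at which 1 of the 3 values shown sits. Among the measured compounds shown here, no two of the measured compounds differ in a single place, so no measured step is available as a yardstick.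

Compound 4 `O=C(NCc1ccc(S(=O)(=O)N2CCCCC2)cc1)c1ccc2nc[nH]c2c1` is not yet measured. It differs from compound 2 by a group of 9 heavy atoms (7 carbon, 2 nitrogen; one five-membered aromatic ring with 2 hetero atoms, one six-membered aromatic ring of carbon only) in place of a group of 9 heavy atoms (7 carbon, 1 nitrogen, 1 sulfur; one five-membered aromatic ring with 1 hetero atom, one six-membered aromatic ring with 1 hetero atom), on a carbonyl carbon. The change concerns the aryl group on the carbonyl carbon only; the piperidinyl sulfonamide side is kept. A step of meaningful size is expected in this assay, toward the weaker side, with wide uncertainty given that the aryl amide group has swung the numbers from that of compound 1 to the limit seen for compound 3. Compound 4 is estimated at 1000 nM, within a range of 200 nM to 8000 nM, which corresponds to an expected step of a 6.7-fold higher number from compound 2 to compound 4 (0.82 log units; beyond the scatter).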

Compound 4, half-maximal inhibitory concentration: 310 nM
The estimate for compound 4 lay 3.2-fold (0.51 log units) above the measured number, within the range that was stated.
By their numbers in this assay, from the lowest: compound 1; then compound 2; then compound 4. At a limit, above all of these: compound 3.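

Among these compounds, with the piperidinyl sulfonamide side held fixed, this assay gives a 2.1-fold higher number from compound 2 to compound 4 (0.32 log units; beyond the scatter), the first measured step and a modest one, on the aryl group on a carbonyl carbon. This shows that the 1H-benzimidazol-6-yl group can take the place of the group in compound 2 at only a modest cost, even though the two differ in ring hetero atoms and hydrogen-bond donor count. Compound 3, which carries a different aryl group and a phenylsulfonyl side rather than the piperidinyl sulfonamide, returns a limit and not a number, so this mild step cannot be taken as general for the position: the limit of > 10000 nM in this assay, at which 1 of the 4 values shown sits.

From the compounds shown here alone, a single step cannot separate the contribution of the hydrogen-bond donor from that of the other ring atom changes, and whether the same exchange would behave alike on the phenylsulfonyl side of compound 1 remains open. A methyl group on the ring nitrogen of the benzimidazole, which removes the amine-type hydrogen while keeping the rings, would bear directly on the first of these questions.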